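This account rests on a few compounds, and the source may have more. Where it says the series, first, only, none or still open, it means among the compounds named here.

Measured compounds:
compound 1, `CC(C)C[C@H](N)c1cc(C(F)(F)F)ccc1N1CCN(C(=O)[C@H]2CCO[C@@H]2c2ccc(Cl)cc2)CC1`, 330 nM
compound 2, `CC(C)[C@H](N)c1cccc(F)c1N1CCN(C(=O)[C@H]2CCO[C@@H]2c2ccc(Cl)cc2)CC1`, 1100 nM

In an assay on HEK293 cells for displacement of a labelled ligand from Melanocortin receptor 4 (Homo sapiens) (on this read-out higher numbers stand for weaker inhibition and lower numbers for stronger inhibition), compound 2 gives 1100 nM, the highest number of the two, while compound 1 gives 330 nM, a gap beyond the scatter. Compound 3, `CC(C)[C@H](N)c1cccc(F)c1N1CCN(C(=O)[C@@H]2CCO[C@@H]2c2ccc(Cl)cc2)CC1`, is not yet measured. It differs from compound 2 as follows: the two compounds have the same atoms and bonds and differ only in configuration as drawn: 1 of 3 stereo elements differ; a stereocentre at a saturated ring carbon is drawn S in compound 2 and R in compound 3. From the compounds shown here alone, both measured compounds carry the configuration drawn in compound 2, so the other configuration is untested here. A change of this kind is expected to lose inhibition, with the step from compound 2 to compound 3 estimated at a 2.7-fold higher number from compound 2 to compound 3 (0.44 log units; beyond the scatter) in this assay. Compound 3 is therefore expected to give about 3000 nM, within 800 nM to 15000 nM.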

Compound 3, inhibition constant: 2100 nM
The estimate for compound 3 lay 1.4-fold (0.15 log units) above the measured number; measured number inside the range.
By their numbers in this assay, from the lowest: compound 1; then compounds 2 and 3 (each within the scatter of the next).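

In this assay, turning the stereocentre at the saturated ring carbon from S to R gives a 1.9-fold higher number from compound 2 to compound 3 (0.28 log units; within the scatter), so the two configurations cannot be told apart at this position. Among the compounds shown here, the earlier compounds carried only the S configuration, and this pair is the first to test the position, with a single stereo element changed: the fact that compounds 2 and 3 differ only in the configuration as drawn.

From the compounds shown here alone, whether the same inversion would read alike on compound 1 stays open. So does the effect of a hydroxyl or a methyl group at this ring carbon.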